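The compounds below may be only part of what the source reports. "The series", "measured", "known", "first", "only" and "open" are said of these compounds alone.

Measured compounds:
compound 1 `COc1ccc2[nH]cc(Cc3c(OC(C)=O)ccc4c(C)cc(=O)oc34)c2c1`: 72000 nM
compound 2 `COc1ccc2c(=O)c(Cc3c(OC(C)=O)ccc4ccc(=O)oc34)c(N(C)C)oc2c1`: 26000 nM
compound 3 `CC(=O)Oc1ccc2ccc(=O)oc2c1Cc1c(-c2ccccc2)[nH]c2ccccc12`: > 100000 nM, a limit of the assay rather than a number

In an ADME assay on MT4 cells (Homo sapiens) for cytotoxicity, read by MTT assay, with a stated time of 96 h (on this read-out lower numbers stand for higher toxicity in this test and higher numbers for lower toxicity in this test), compound 2 gives 26000 nM, the lowest of the two numbers at hand. In this assay compound 1 gives 72000 nM, a higher number than compound 2 by a gap beyond the usual scatter. For compound 3 this assay yields only a limit, > 100000 nM, as noted in the limit of > 100000 nM in this assay, at which 1 of the 3 values shown sits. Among the compounds with values here, no pair of the measured compounds differs in a single place, so no measured step is available to gauge how one change shifts the read-out.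

The unmeasured compound 4 `COc1ccc2c(=O)c(Cc3c(OC(C)=O)ccc4ccc(=O)oc34)c(N3CCCC3)oc2c1` follows from compound 2 by one change: pyrrolidin-1-yl in place of dimethylamino on an aromatic carbon. Among the three measured compounds nothing shows how such an exchange moves this assay. The expectation is a step from compound 2 to compound 4 of a 1.3-fold lower number from compound 2 to compound 4 (0.11 log units; within the scatter), small and likely within the scatter, if anything toward a lower number. Compound 4 is therefore estimated at 20000 nM with a range from 8000 nM to 60000 nM.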

Compound 4, half-maximal cytotoxic concentration: > 100000 nM
Compound 4 ended at the assay's limit (the forecaster's own chance of this, stated with the estimate: 10%); middle value at least 5.0-fold (0.69 log units) away from the limit.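

Pyrrolidin-1-yl in place of dimethylamino, on the aromatic carbon next to the ring oxygen, gives the first single-place comparison in the series: in this assay the read-out shows an at least 3.8-fold higher number from compound 2 to compound 4 (0.58 log units; beyond the scatter). Compound 4 gives > 100000 nM, which is a limit of the assay and not a number: the limit of > 100000 nM in this assay, at which 2 of the 4 values shown sit. This position on the shared core can therefore move the read-out beyond the scatter with nothing else changed, here toward lower toxicity in this test.

As far as these compounds go, the full size of the step remains open, as its upper end lies past the limit. From the compounds shown here alone, it is also open whether the step goes with the ring itself or with the added carbons: diethylamino at the same carbon would separate the two, and morpholin-4-yl would show the effect of a further ring hetero atom.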